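A Pyrrolidine Amide Tried on a Weakly Active Core

The source may hold more compounds than are shown below. What is called first, only, known or untested is meant among the compounds shown, and "the series" means these compounds.

Of the compounds shown here, three on the shared core have been tested in a functional assay on MIA PaCa-2 cells (Homo sapiens) for inhibition, read by MTT assay, with a stated time of 3 days; a lower number here means a stronger inhibitor, a higher number a weaker inhibitor. Compound 1 `O=C([C@@H]1CCCN(S(=O)(=O)c2ccc(S(=O)(=O)C3CCC3)cc2)C1)N1CCC(F)(F)CC1` gives only a limit in this assay, > 3000 nM. Compound 2 `O=C([C@@H]1CCCN(S(=O)(=O)c2ccc(S(=O)(=O)N3CC[C@@H](O)C3)cc2)C1)N1CCC(F)(F)CC1` likewise gives only a limit in this assay, > 3000 nM. The change a step that the two limits leave unreadable from compound 1 to compound 2 cannot be sized because both values sit at the limit of > 3000 nM in this assay, at which 2 of the 3 values shown sit.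

Compound 3 `CCN(CC)S(=O)(=O)c1ccc(S(=O)(=O)N2CCC[C@@H](C(=O)N3CCOCC3)C2)cc1` also stands at a limit rather than a number: in this assay compound 3 gives > 10000 nM, which is the limit of > 10000 nM in this assay, at which 1 of the 3 values shown sits. Of the three values shown, none is a real number, so compound 3 cannot be placed above or below the others.

Compound 4 `CCN(CC)S(=O)(=O)c1ccc(S(=O)(=O)N2CCC[C@@H](C(=O)N3CC[C@H](OC)C3)C2)cc1` differs from compound 3 in one place: 3-methoxypyrrolidin-1-yl in place of morpholin-4-yl on a carbonyl carbon. Within the data shown here, no measured step touches a carbonyl carbon; the only comparison available is at a sulfonyl sulfur, and it is unreadable. No direction beyond the scatter is therefore expected, and the most likely outcome for compound 4 is another limit. The step from compound 3 to compound 4 is expected to be a number no higher from compound 3 to compound 4 (the limit leaves the size open). For compound 4 the estimate is 10000 nM, expected to lie between 3000 nM and 30000 nM.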

Compound 4, half-maximal inhibitory concentration: > 10000 nM
Compound 4 was reported as a limit (the forecaster's own chance of this, stated with the estimate: 80%); the middle value lies on the limit itself.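

Compound 3 and compound 4 both stand at a limit rather than a real number, so the step between them cannot be read: the limit of > 10000 nM in this assay, at which 2 of the 4 values shown sit.

The compounds shown leave open whether any change on the shared core can give a real number rather than a limit.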